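Anilinopyrimidine substitution on two quinoline-bearing cores

This account rests on a few compounds, and the source may have more. Where it says the series, first, only, none or still open, it means among the compounds named here.

Measured compounds:
compound 1 `Cc1ccc(Nc2nccc(-c3ccnc4ccccc34)n2)cc1` with 50.9%
compound 2 `Nc1nccc(-c2ccnc3ccccc23)n1` with 9.4%
compound 3 `Nc1nccc(-c2cnc3ccccc3c2)n1` with "not active" (no number reported)

The three measured compounds were tested in a functional assay on K562 cells (Homo sapiens) for cytotoxicity, read by sulforhodamine B assay, with a stated time of 48 h, tested at 50 uM; on this read-out higher numbers stand for more inhibition at the one concentration tested (going by the name of the read-out) and lower numbers for less inhibition. Compound 2 gives 9.4% in this assay, and compound 1 gives 50.9%. The two differ at one place: 4-methylphenyl in place of hydrogen on a nitrogen on an aromatic ring. The step of a number 41.5 percentage points higher from compound 2 to compound 1 (beyond the scatter) is the only measured step of this change among the compounds shown, and it is large.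

Compound 3 was reported as not active in this assay, without a number. Its core and the core of compound 2 hold the same atoms joined differently; the difference between the two cores is not broken down here.

Compound 4 `Cc1ccc(Nc2nccc(-c3cnc4ccccc4c3)n2)cc1` has not yet been measured. It stands to compound 3 as compound 1 stands to compound 2: 4-methylphenyl in place of hydrogen on a nitrogen on an aromatic ring. The place of the change is the same in both pairs, so the change is the same, made twice in all among these compounds. Its size is known only once, from compound 2 to compound 1. Whether the new core carries it alike is not known, and compound 3 has no number that would fix the starting point.

Compound 4 is expected to reach about 38% in this assay, since the same change gave a number 41.5 percentage points higher from compound 2 to compound 1 (beyond the scatter) from a starting point that was itself low. For compound 4 the estimate is expected to span from 8% to 60%. Going by the values given here, this width reflects that only one measured step, a number 41.5 percentage points higher from compound 2 to compound 1 (beyond the scatter), supports the estimate.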

Compound 4, a percentage reported as inhibition, at one concentration (the size of the read-out at that concentration, not a potency): "not active" (no number reported)
Compound 4 has no reported number here, and the estimate cannot be compared.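

Compound 3 and compound 4 were both reported as not active in this assay, without a number, so no step can be read between them. Nothing shown here offers an explanation for this result. The compounds shown leave open whether the change from amino to (4-methylphenyl)amino has any effect on the core of compound 3 comparable to its effect on the core of compound 2.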